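Hydroxy in Place of Hydrogen: From Compound 1 to Compound 3

The compounds below may be only part of what the source reports. "The series", "measured", "known", "first", "only" and "open" are said of these compounds alone.

This account follows a single change made to compound 1, whose structure is `O=C(NCCO)c1cccc2c1CCN2c1nccc(Cc2cc(F)cc(C(F)(F)F)c2)n1`. In a functional assay on HEK293 cells for agonist activity at G-protein coupled receptor 52 (Homo sapiens), read by cAMP accumulation, with a stated time of 15 min (on this read-out higher numbers stand for larger maximal responses and lower numbers for smaller maximal responses), compound 1 gives 138%, the highest of the two numbers recorded here. Among the compounds with values here, the only other measured compound, compound 2, has the structure `O=C(NCCO)c1cccc2c1CCN2c1nncc(Cc2cc(F)cc(C(F)(F)F)c2)c1Cl`; in this assay compound 2 gives 97%, a value that lies beyond the usual scatter below that of compound 1. The two measured compounds differ in more than one place. No single step can be read from them, and the comparison says only what the two values show.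

The unmeasured compound is compound 3, with the structure `O=C(NCCO)c1cccc2c1CCN2c1nccc(C(O)c2cc(F)cc(C(F)(F)F)c2)n1`. Relative to compound 1 the change is hydroxy in place of hydrogen on a saturated chain carbon bound to two aromatic carbons. Within the data shown here, no measured pair isolates such a change, so the expected outcome rests on compound 1 alone. The author expects the step of a number 28 percentage points lower from compound 1 to compound 3 (beyond the scatter) to be downward and of moderate size, probably beyond the scatter. For compound 3 in this assay the estimate is 110%, with a range from 60% to 150%.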

Compound 3, largest response reached (Emax), in percent of the reference or control that the assay uses: 130%
Compound 3: middle estimate off by 20 percentage points, on the low side; measured number inside the range.
By their numbers in this assay, from the lowest: compound 2; then compounds 3 and 1 (each within the scatter of the next).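

Within the data shown here, the step of a number 8 percentage points lower from compound 1 to compound 3 (within the scatter) in this assay is the first change at a single place that can be read, since compounds 1 and 2 differ in more than one place. It shows that, with the rest of compound 1 unchanged, hydroxy in place of hydrogen on a saturated chain carbon bound to two aromatic carbons produces no difference in maximal response that this read-out can separate from the usual scatter, even though the change adds a hydrogen-bond donor and a hydrogen-bond acceptor at this position. No measurement here bears on why the response stays within the scatter, and the result offers no explanation of its own.

As far as these compounds go, what a methoxy group, an amine or a fluorine atom would do on the same carbon remains open, and so does the effect of a carbonyl at that position. From the compounds shown here alone, it is also open whether hydroxy in place of hydrogen would read the same way on another core, such as that of compound 2, as this single step supports no pattern beyond compounds 1 and 3.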